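The compounds below may be only part of what the source reports. "The series", "measured", "known", "first", "only" and "open" are said of these compounds alone.

Measured so far in a physicochemical assay for lipophilicity, read by HPLC, in phosphate buffer, measured as octanol-water partition, with a stated time of 1 h, at pH 7.4; on this read-out higher numbers stand for higher lipophilicity and lower numbers for lower lipophilicity:
- compound 1 `Cc1cc(C#N)cnc1C(=O)Nc1ccc(F)c([C@]2(C)C=C(CF)OC(N)=N2)c1`: 2.5
- compound 2 `C[C@@]1(c2cc(NC(=O)c3cnc(C(F)F)cn3)ccc2F)C=C(CF)OC(N)=N1`: 2.5
- compound 3 `C[C@@]1(c2cc(NC(=O)c3ncc(OCF)nc3N)ccc2F)C=C(CF)OC(N)=N1`: 3.1

Compound 3 stands highest of the three in this assay. The two steps that reach it are a number 0.60 log units higher from compound 1 to compound 3 (beyond the scatter) and a number 0.60 log units higher from compound 2 to compound 3 (beyond the scatter). Between the other two, the data show no change at the digits printed from compound 1 to compound 2 (within the scatter).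

Next is compound 4 `C[C@@]1(c2cc(NC(=O)c3coc(CF)n3)ccc2F)C=C(CF)OC(N)=N1`, with this change: 2-(fluoromethyl)-1,3-oxazol-4-yl in place of 3-amino-5-(fluoromethoxy)pyrazin-2-yl on a carbonyl carbon. It gives up the 3-amino-5-(fluoromethoxy)pyrazin-2-yl group, and both measured compounds without that group read lower, as the two steps into compound 3 show. Those steps are modest and equal in size, and they are the closest guide, read in reverse. For the measured compounds named here, no measured compound carries the 2-(fluoromethyl)-1,3-oxazol-4-yl group, so the entering side remains uncertain and the range stays wide.

A modest fall of similar size or slightly more is expected, estimated as a number 0.80 log units lower from compound 3 to compound 4 (beyond the scatter). The estimate for compound 4 is 2.3, with an expected range of 1.8 to 2.8.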

Compound 4, distribution coefficient: 2.2
Compound 4: the middle estimate sits 0.10 log units above what was measured; measured number inside the range.
By their numbers in this assay, from the lowest: compounds 4, 1 and 2 (each within the scatter of the next); then compound 3.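

In this assay the position on the carbonyl carbon now shows a step with a five-membered aromatic ring entering: a number 0.90 log units lower from compound 3 to compound 4 (beyond the scatter). The same group set against the other two gives a number 0.30 log units lower from compound 2 to compound 4 (within the scatter) and a number 0.30 log units lower from compound 1 to compound 4 (within the scatter), so compound 1, compound 2 and compound 4 form one group, despite their different rings, and only compound 3 stands apart from the rest. No measurement at hand explains these steps.

The change from compound 3 to compound 4 alters the ring, the hydrogen-bond donors and the hydrogen-bond acceptors at once, so the compounds shown cannot assign the step to any one of these. A 5-(fluoromethoxy)pyrazin-2-yl group lacking the amine would separate the amine's share from that of the fluoromethoxy group.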